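Working notes on three measured compounds and one pending analogue

The compounds below may be only part of what the source reports. "The series", "measured", "known", "first", "only" and "open" are said of these compounds alone.

Measured so far:
compound 1, `Cc1ccc(-c2nnc(NC(=O)/C=C/c3ccc(C(F)(F)F)cc3)s2)cc1`: 1.61 ug/mL
compound 2, `O=C(/C=C/c1ccccc1)Nc1nnc(-c2ccc(Cl)cc2)s1`: 2.02 ug/mL
compound 3, `O=C(/C=C/c1ccccc1)Nc1nnc(-c2ccccc2)s1`: 1.75 ug/mL

All three numbers come from a functional assay on A549 cells (Homo sapiens) for antiproliferative activity, read by MTT assay, with a stated time of 48 h; on this read-out higher numbers stand for weaker inhibition and lower numbers for stronger inhibition. The three values lie within the usual scatter of one another; compound 1 is nearest to compound 3 and furthest from compound 2, and both gaps are inside the scatter, so no ordering among them is claimed.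

The pending compound is compound 4, `Cc1ccc(/C=C/C(=O)Nc2nnc(-c3ccc(C)cc3)s2)cc1`. Relative to compound 1 the change is methyl in place of trifluoromethyl on an aromatic carbon, sitting para to a large group on a six-membered aromatic ring of carbon only.

For the measured compounds named here, the only measured step at a comparable place is a 1.2-fold lower number from compound 2 to compound 3 (0.06 log units; within the scatter), a swap of one small substituent for another on an aromatic carbon that left the number essentially unchanged. By that single step, and with no contrary evidence in the series, the exchange in compound 4 is expected to give no step beyond the scatter in this assay.

Compound 4 is therefore estimated at 1.7 ug/mL, with a range of 0.8 ug/mL to 3.6 ug/mL. That estimate means a 1.1-fold higher number from compound 1 to compound 4 (0.02 log units; within the scatter), expected to stay within the scatter.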

Compound 4, half-maximal inhibitory concentration: 1.08 ug/mL
Compound 4: middle estimate off by 1.6-fold (0.20 log units), on the high side; the measured number falls inside the stated range.
By their numbers in this assay, from the lowest: compounds 4, 1, 3 and 2 (each within the scatter of the next).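

In this assay, methyl in place of trifluoromethyl gives a 1.5-fold lower number from compound 1 to compound 4 (0.17 log units; within the scatter), so replacing a group of 4 heavy atoms, 3 of them fluorine, with a single carbon moves the number no further than the scatter. For the compounds shown here, this is the first reading at this place, on an aromatic carbon para to a large group, and it extends the picture beyond the chloro-to-hydrogen swap, which sits elsewhere in the molecule. No supporting data bear on why the change leaves the number within the scatter.

With only trifluoromethyl and methyl shown at this place, the limits of what it accepts remain undefined. An amine, a carboxylic acid or a longer alkyl chain here could still give a step beyond the scatter, and only such a result would show whether this place matters for the read-out.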